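This account rests on a few compounds, and the source may have more. Where it says the series, first, only, none or still open, it means among the compounds named here.

Working notes on the series. In a functional assay on B16-F10 cells (Mus musculus) for antiproliferative activity, read by MTT assay, with a stated time of 48 h (on this read-out lower numbers stand for stronger inhibition and higher numbers for weaker inhibition), compound 1 `O=C(/C=C/c1ccc(O)c(O)c1)N1CCN(c2cccc(Cl)c2)CC1` gives 1.71 ug/mL and compound 2 `COc1cccc(N2CCN(C(=O)/C=C/c3ccc(O)c(O)c3)CC2)c1` gives 1.46 ug/mL. The measured step, a 1.2-fold lower number from compound 1 to compound 2 (0.07 log units; within the scatter), lies within the scatter, so compound 2 stands level with compound 1 and the two cannot be ranked.

Compound 3 `O=C(/C=C/c1ccc(O)c(O)c1)N1CCN(c2cccc(C(F)(F)F)c2)CC1` is the next entry, and its change from compound 2 is trifluoromethyl in place of methoxy on an aromatic carbon, meta to a large group. Among the compounds with values here, no measured compound yet carries trifluoromethyl. Within the data shown here, the only evidence is the exchange of chloro for methoxy at this place, and that step stayed within the scatter. No step beyond the scatter is therefore expected in this assay, in either direction, though this rests on one pair alone. The expected change is a 1.2-fold higher number from compound 2 to compound 3 (0.07 log units; within the scatter). For compound 3 the estimate is 1.7 ug/mL, with an expected range of 0.9 ug/mL to 3.2 ug/mL.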

Compound 3, half-maximal inhibitory concentration: 2.01 ug/mL
Estimate against measurement, compound 3: 1.2-fold (0.07 log units) below; low and high end bracket the measured number.
By their numbers in this assay, from the lowest: compounds 2, 1 and 3 (each within the scatter of the next).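

In this assay trifluoromethyl on this aromatic carbon, meta to a large group, gives a 1.4-fold higher number from compound 2 to compound 3 (0.14 log units; within the scatter) against methoxy and a 1.2-fold higher number from compound 1 to compound 3 (0.07 log units; within the scatter) against chloro, so compound 1, compound 2 and compound 3 cannot be ranked. Within the data shown here, the single exchange of the earlier pair now has company: methoxy, chloro and trifluoromethyl all stand level at this place, and the hydrogen-bond acceptor counted for methoxy is gone in compound 3 with no step beyond the scatter. No measured evidence bears on the reason for this flat result.

From the compounds shown here alone, whether a group of another kind at this place, such as an amine or a carboxylic acid, would give a step beyond the scatter stays open. Also open, going by these compounds, is whether changes elsewhere in the shared core would matter more than this exchange.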